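A few compounds are considered here, and "the series" means these few. Any claim that something is new, unique, unknown or untested is made for them only; others in the source may bear on it.

Working notes on the series. Compound 1 `Fc1ccc(C2CC(c3ccc(Cl)cc3)=NN2c2ccc(-c3ccccc3)nn2)cc1` gives 3750 nM in a functional assay on MCF7 cells (Homo sapiens) for antiproliferative activity, read by MTT assay, with a stated time of 24 h; on this read-out lower numbers stand for stronger inhibition and higher numbers for weaker inhibition. Compound 2 `COc1cc(C2CC(c3ccc(Cl)cc3)=NN2c2ccc(-c3ccccc3)nn2)cc(OC)c1OC` gives 100000 nM in this assay, which is a step of a 27-fold higher number from compound 1 to compound 2 (1.43 log units; beyond the scatter). Compound 3 `COc1ccc(C2=NN(c3ccc(-c4ccccc4)nn3)C(c3ccc(F)cc3)C2)cc1` gives 20000 nM in this assay, a step of a 5.3-fold higher number from compound 1 to compound 3 (0.73 log units; beyond the scatter). Among the three numbers, compound 3 stands second highest: compound 2 lies a further step up from it and compound 1 a step down, both gaps beyond the scatter.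

Compound 4 `COc1ccc(C2=NN(c3ccc(-c4ccccc4)nn3)C(c3cc(OC)c(OC)c(OC)c3)C2)cc1` has not yet been run in this assay. It differs from compound 3 by 3,4,5-trimethoxyphenyl in place of 4-fluorophenyl on a saturated ring carbon. The same change has been made once before, on the chloro-bearing pair, where it produced a 27-fold higher number from compound 1 to compound 2 (1.43 log units; beyond the scatter), a large move to a weaker number. For the measured compounds named here, that is the only measured step bearing on the question, and a move of similar size and the same direction is expected here, namely a 5.0-fold higher number from compound 3 to compound 4 (0.70 log units; beyond the scatter). Compound 3 already starts from 20000 nM, a weak number in this assay. For compound 4 the estimate in this assay is therefore 100000 nM, in a range from 30000 nM to 400000 nM, with a fair chance that the run returns only a limit.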

Compound 4, half-maximal inhibitory concentration: 100000 nM
Estimate against measurement, compound 4: no gap at the digits printed; measured number inside the range.
By their numbers in this assay, from the lowest: compound 1; then compound 3; then compounds 2 and 4 (each within the scatter of the next).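

On the methoxy-bearing core, 3,4,5-trimethoxyphenyl in place of 4-fluorophenyl on the saturated ring carbon gives a 5.0-fold higher number from compound 3 to compound 4 (0.70 log units; beyond the scatter), so the direction holds on both cores shown in this assay, but the size does not carry over: the same change on two cores in this assay, a 27-fold higher number (1.43 log units; beyond the scatter) from compound 1 to compound 2 and a 5.0-fold higher number (0.70 log units; beyond the scatter) from compound 3 to compound 4, 5.3-fold (0.73 log units) apart, beyond the scatter of two such steps

Methoxy in place of chloro on the aromatic carbon gives no change at the digits printed from compound 2 to compound 4 (within the scatter) once 3,4,5-trimethoxyphenyl occupies the saturated ring carbon, so that change does not behave alike on the two cores: the same change on two cores in this assay, a 5.3-fold higher number (0.73 log units; beyond the scatter) from compound 1 to compound 3 and no change at the digits printed (within the scatter) from compound 2 to compound 4, 5.3-fold (0.73 log units) apart, beyond the scatter of two such steps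

Across these four compounds, the chloro and methoxy pair differ in number only when 4-fluorophenyl is present.

The compounds shown leave open which of the three methoxy groups accounts for the weaker numbers, and how a phenyl carrying a single methoxy group would read. They also leave open whether an unsubstituted phenyl or a phenyl bearing a dimethylamino group on the saturated ring carbon could give a lower number than compound 1.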